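The compounds below may be only part of what the source reports. "The series", "measured", "known", "first", "only" and "open" are said of these compounds alone.

In an ADME assay on MDCK cells (Canis lupus familiaris) for permeability, in the apical to basolateral direction (on this read-out lower numbers stand for lower permeability and higher numbers for higher permeability), compound 1 `CC(C)C(c1ccc(-c2ccc3cccc(F)c3c2)[nH]c1=O)C1NC(=O)NC1=O` has no single number, since compound 1 is reported as "not determined" (no result reported). The same holds for compound 2 `CC(C)C1(c2ccc(-c3ccc4ccccc4c3)[nH]c2=O)OC(=O)NC1=O`, and compound 2 is reported as "not determined" (no result reported). Going by the values given here, the only number so far comes from compound 3 `CC(C)/C(=C1\C(=O)NC(=O)N1C)c1ccc(-c2ccc3cccc(F)c3c2)[nH]c1=O`, and compound 3 gives 6.85 10^-6 cm/s. Compound 4 `CC(C)C(/C=C1/C(=O)NC(=O)N1C)c1ccc(-c2ccc3cccc(F)c3c2)[nH]c1=O` is still unmeasured, and it differs from compound 1 in one place: a group of 9 heavy atoms (5 carbon, 2 nitrogen, 2 oxygen; one five-membered non-aromatic ring with 2 hetero atoms) in place of a group of 7 heavy atoms (3 carbon, 2 nitrogen, 2 oxygen; one five-membered non-aromatic ring with 2 hetero atoms), on a saturated chain carbon bound to an aromatic carbon and a saturated chain carbon. Among the compounds with values here, with no number for compound 1, no step from it can be sized, so the only anchor is compound 3 at 6.85 10^-6 cm/s, and no shift beyond the usual scatter of this assay from that value is expected. For compound 4 the estimated value is 7 10^-6 cm/s, with an expected range of 3 10^-6 cm/s to 15 10^-6 cm/s.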

Compound 4, apparent permeability: 14.1 10^-6 cm/s
The estimate for compound 4 lay 2.0-fold (0.30 log units) below the measured number; measured number inside the range.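

Going by these compounds alone, the pair compound 1 and compound 4 gives no step that can be read in this assay. No supporting data bear on the result for compound 4. The compounds shown leave open how swapping the 2,5-dioxoimidazolidin-4-yl group alone shifts this read-out.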